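Methoxy to fluoro on the pendant aryl: compound 3

This account rests on a few compounds, and the source may have more. Where it says the series, first, only, none or still open, it means among the compounds named here.

Measured so far:
compound 1, `Cc1ccc(C2=Nn3c(nnc3C(C)c3ccc(CC(C)C)cc3)SC2)cc1`: 7300 nM
compound 2, `COc1ccc(C2=Nn3c(nnc3C(C)c3ccc(-c4ccccc4)c(F)c3)SC2)cc1`: 4200 nM

Two compounds of the series have been run in a functional assay on HepG2 cells (Homo sapiens) for inhibition, read by sulforhodamine B assay, with a stated time of 72 h; a lower number here means a stronger inhibitor, a higher number a weaker inhibitor. Compound 2 gives 4200 nM, the lowest of the two numbers, but compound 1 with 7300 nM lies within the scatter of it, so no order between the two can be claimed. The two also differ at more than one place, so no single step can be read from them.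

Compound 3, `CC(c1ccc(-c2ccccc2)c(F)c1)c1nnc2n1N=C(c1ccc(F)cc1)CS2`, has not yet been measured. It differs from compound 2 in one place: fluoro in place of methoxy on an aromatic carbon. The change sits on the six-membered aromatic ring of carbon only, para to a large group, and it reads at the next bond out as 4-methoxyphenyl to 4-fluorophenyl.

For the measured compounds named here, nothing among the measured compounds isolates this change, so the direction of its effect is unknown. With that reservation, compound 3 is expected to land near compound 2, and the estimated step of a 1.2-fold higher number from compound 2 to compound 3 (0.08 log units; within the scatter) is expected to stay within the scatter. The estimate for compound 3 in this assay is 5000 nM, with a range of 2000 nM to 13000 nM.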

Compound 3, half-maximal inhibitory concentration: 5100 nM
Compound 3: middle estimate off by 1.0-fold (0.01 log units), on the low side, within the range that was stated.
By their numbers in this assay, from the lowest: compounds 2, 3 and 1 (each within the scatter of the next).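

In this assay, going from 4-methoxyphenyl to 4-fluorophenyl gives a 1.2-fold higher number from compound 2 to compound 3 (0.08 log units; within the scatter), so the two compounds cannot be told apart and this single exchange shows no effect that can be claimed. For the compounds shown here, this is the first reading of this position on its own: fluoro, with one heavy atom and no hydrogen-bond acceptor, stands in place of methoxy, with two heavy atoms and one hydrogen-bond acceptor, and the step stays within the scatter. No measurement at hand bears on why the two compounds read alike.

From the compounds shown here alone, whether this position stays as flat with an amine, a carboxylic acid or a longer alkoxy chain remains open, since methoxy and fluoro alone cover only a narrow part of what could sit on this aromatic carbon. Going by these compounds, compound 1 differs from compound 2 and compound 3 at more than one place, so steps to it cannot be read, and whether the fluoro and methoxy result carries over to its other substituents also remains open.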